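Adding a Nitro Group to a Pyrazoline Cytotoxic Screen

The compounds below may be only part of what the source reports. "The series", "measured", "known", "first", "only" and "open" are said of these compounds alone.

Compound 1 `CC(=O)N1N=C(c2ccco2)CC1c1ccccc1[N+](=O)[O-]`: 28300 nM
Compound 2 `O=CCN1N=C(c2ccc3ccccc3c2)CC1c1ccccc1`: 21500 nM

In a functional assay on OVCAR cells (Homo sapiens) for cytotoxicity, read by sulforhodamine B assay, with a stated time of 48 h (a lower number here means a stronger inhibitor, a higher number a weaker inhibitor), compound 2 gives the lowest of the two numbers, yet compound 1 lies within the scatter of it, so no order between the two can be claimed. Compound 3 `O=CCN1N=C(c2ccc3ccccc3c2)CC1c1cccc([N+](=O)[O-])c1` differs from compound 2 by nitro in place of hydrogen on an aromatic carbon. Among the compounds with values here, no measured pair shows this change, so a step within the scatter, in either direction, is expected as a 1.1-fold lower number from compound 2 to compound 3 (0.03 log units; within the scatter). Compound 3 is thus estimated at 20000 nM, between 7000 nM and 60000 nM.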

Compound 3, half-maximal inhibitory concentration: 3390 nM
Compound 3: the middle estimate sits 5.9-fold (0.77 log units) above what was measured; the measured number lies below the stated range.
By their numbers in this assay, from the lowest: compound 3; then compounds 2 and 1 (each within the scatter of the next).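

In this assay, the change from phenyl to 3-nitrophenyl gives a 6.3-fold lower number from compound 2 to compound 3 (0.80 log units; beyond the scatter), so this aromatic carbon, meta to a large group, is a place where a substituent can alter the number. Compounds 1 and 2 differ in more than one place, so they could not show this for any single position. No measurement at hand accounts for the step.

On these data alone, whether an amine or a nitrile at this carbon would give a similar step stays open. So does the effect of nitro on another carbon of that ring.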